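The source may report more compounds than this note shows. Statements on the series, on what has been measured and on what is new or still open speak of the compounds shown alone.

Three measured compounds share one core and differ only in the group on a carbonyl carbon. Compound 1 `CC(=O)Nc1nn(-c2ccccc2)c(=O)c2ccccc12` carries a methyl there and gives 52% in an assay on CHO cells for displacement of a labelled ligand from adenosine receptor A1 (Homo sapiens), tested at 10 uM; a higher number here means more inhibition at the concentration tested (going by the name of the read-out), a lower number less inhibition. Compound 2 `O=C(Nc1ccc(Cl)cc1)Nc1nn(-c2ccccc2)c(=O)c2ccccc12` gives 10% in this assay, and compound 3 `COc1ccc(C(=O)Nc2nn(-c3ccccc3)c(=O)c3ccccc23)cc1` gives 0%. Of the three numbers that of compound 3 is the lowest as written, but compound 2 lies within the scatter of it, and only compound 1 stands beyond the scatter above it. Both a number 42 percentage points lower from compound 1 to compound 2 (beyond the scatter) and a number 52 percentage points lower from compound 1 to compound 3 (beyond the scatter) were large drops, whereas a number 10 percentage points lower from compound 2 to compound 3 (within the scatter) stayed within the scatter.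

Compound 4 `COc1ccc(NC(=O)Nc2nn(-c3ccccc3)c(=O)c3ccccc23)cc1` differs from compound 3 by (4-methoxyphenyl)amino in place of 4-methoxyphenyl on a carbonyl carbon. Going by the values given here, the step that bears most on this change is the one from compound 2 to compound 3, which is the same kind of exchange in the reverse direction and stayed within the scatter; compound 2 also shows directly that such an amino-linked group gives a small number. Compound 4 is therefore expected to stay near the bottom, with an expected step of a number 6 percentage points higher from compound 3 to compound 4 (within the scatter) that lies within the scatter. The estimate for compound 4 in this assay is 6%, with a range from 0% to 20%.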

Compound 4, a percentage reported as inhibition, at one concentration (the size of the read-out at that concentration, not a potency): 4%
Compound 4: middle estimate off by 2 percentage points, on the high side; measured number inside the range.
By their numbers in this assay, from the lowest: compounds 3, 4 and 2 (each within the scatter of the next); then compound 1.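

In this assay, the exchange of methoxy for chloro on an aromatic carbon gives a number 6 percentage points lower from compound 2 to compound 4 (within the scatter), and the insertion of the amino link with the 4-methoxyphenyl group kept gives a number 4 percentage points higher from compound 3 to compound 4 (within the scatter), so each of the two changes that were combined in the step between compound 2 and compound 3 can now be read alone, and neither moves the number beyond the scatter. With a number 48 percentage points lower from compound 1 to compound 4 (beyond the scatter), a third group carrying a six-membered aromatic ring on the carbonyl carbon stands well under the methyl of compound 1, and none of the listed compounds goes against this. Nothing at hand explains these numbers.

The compounds shown leave open whether a group only slightly larger than methyl on the carbonyl carbon, such as ethyl or methylamino, would keep the number of compound 1 or fall toward those of the other three. They also leave open whether an amine or a carboxylic acid in place of methoxy on an aromatic carbon would give a number that stands apart from those of compound 2 and compound 4.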